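From 2,3-dihydroxyphenyl to 2,5-dihydroxyphenyl in compound 4

This account rests on a few compounds, and the source may have more. Where it says the series, first, only, none or still open, it means among the compounds named here.

Values in a functional assay, with a stated time of 30 min; on this read-out lower numbers stand for stronger inhibition and higher numbers for weaker inhibition:
- Compound 1 `O=C(/C=C/c1ccc(O)c(O)c1)CC(=O)/C=C/c1cccc(O)c1O`: 19000 nM
- Compound 2 `O=C(/C=C/c1cccc(O)c1O)CC(=O)/C=C/c1cccc(O)c1O`: 30000 nM
- Compound 3 `O=C(/C=C/c1ccc(O)cc1)CC(=O)/C=C/c1cccc(O)c1O`: 27000 nM

Compound 1 cannot be separated from the other two compounds, since its steps to both lie within the scatter: a 1.6-fold higher number from compound 1 to compound 2 (0.20 log units; within the scatter) and a 1.4-fold higher number from compound 1 to compound 3 (0.15 log units; within the scatter) (the remaining step is a 1.1-fold lower number from compound 2 to compound 3 (0.05 log units; within the scatter) and lies within it too). Compound 4 `O=C(/C=C/c1ccc(O)c(O)c1)CC(=O)/C=C/c1cc(O)ccc1O` has not yet been measured. It differs from compound 1 in one group, 2,5-dihydroxyphenyl in place of 2,3-dihydroxyphenyl on a double-bonded chain carbon bound to a double-bonded chain carbon (the 3,4-dihydroxyphenyl group stays in place). Going by the values given here, none of the measured steps touches this group, as all three measured compounds keep their 2,3-dihydroxyphenyl. They bear on the question only indirectly: changes to the other group of compound 1 gave a 1.6-fold higher number from compound 1 to compound 2 (0.20 log units; within the scatter) and a 1.4-fold higher number from compound 1 to compound 3 (0.15 log units; within the scatter) without leaving the scatter. The data therefore favour no direction, and the step expected in this assay is a 1.1-fold higher number from compound 1 to compound 4 (0.02 log units; within the scatter) (nothing beyond the scatter). For compound 4 the estimated value is 20000 nM (expected range 8000 nM to 45000 nM).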

Compound 4, half-maximal inhibitory concentration: 60000 nM
Compound 4: the middle estimate sits 3.0-fold (0.48 log units) below what was measured, and the stated range ends below it.
By their numbers in this assay, from the lowest: compounds 1, 3, 2 and 4 (each within the scatter of the next, the first and the last beyond it).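

In this assay, going by these compounds alone, putting 2,5-dihydroxyphenyl in place of 2,3-dihydroxyphenyl gives a 3.2-fold higher number from compound 1 to compound 4 (0.50 log units; beyond the scatter), the only step in this set that leaves the scatter. The two groups have the same atoms and the same counts of hydrogen-bond donors and acceptors, so at this place on the chain the read-out separates two arrangements of the hydroxy groups that those counts cannot tell apart. Nothing shown here accounts for the weaker inhibition. Within the data shown here, with only this one change made to the group, it remains open whether the step would be of similar size if the other side of the molecule carried the 4-hydroxyphenyl group of compound 3 instead of the 3,4-dihydroxyphenyl group. Also open, on these data alone, is how this assay would respond if an amine or a carboxylic acid replaced one hydroxy group of this ring.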